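From 2-nitrophenyl to 3-nitrophenyl: an expected small shift

The source may hold more compounds than are shown below. What is called first, only, known or untested is meant among the compounds shown, and "the series" means these compounds.

In a functional assay on MCF7 cells (Homo sapiens) for cytotoxicity, read by sulforhodamine B assay (a lower number here means a stronger inhibitor of growth, a higher number a weaker inhibitor of growth), compound 1 `CC1=CC[C@@H]([C@@](C)(O)CCCC(C)(C)NC(=S)N/N=C\c2ccccc2)CC1` gives 7720 nM and compound 2 `COc1ccc(/C=N\NC(=S)NC(C)(C)CCC[C@](C)(O)[C@@H]2CC=C(C)CC2)cc1` gives 6500 nM, a difference of a 1.2-fold lower number from compound 1 to compound 2 (0.07 log units; within the scatter). Compound 3 `CC1=CC[C@@H]([C@@](C)(O)CCCC(C)(C)NC(=S)N/N=C\c2ccccc2[N+](=O)[O-])CC1` has the highest number of the three at 18600 nM. Compound 4 `CC1=CC[C@@H]([C@@](C)(O)CCCC(C)(C)NC(=S)N/N=C\c2cccc([N+](=O)[O-])c2)CC1` differs from it by 3-nitrophenyl in place of 2-nitrophenyl on a carbon with a double bond to nitrogen, with 3-nitrophenyl in place of 2-nitrophenyl on a carbon with a double bond to nitrogen. The step bearing most directly is a 2.4-fold higher number from compound 1 to compound 3 (0.38 log units; beyond the scatter), the only measured addition of a nitro group, while a 2.9-fold higher number from compound 2 to compound 3 (0.46 log units; beyond the scatter) is of similar size. For the measured compounds named here, no measured pair moves a nitro group, so only a partial return toward the number of compound 1 is expected. The expected change is a 1.7-fold lower number from compound 3 to compound 4 (0.23 log units; within the scatter), toward a lower number. For compound 4 the estimate is 11000 nM, with an expected range of 5500 nM to 22000 nM.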

Compound 4, concentration for 50% growth inhibition: 6720 nM
The estimate for compound 4 lay 1.6-fold (0.21 log units) above the measured number; the range from low to high includes it.
By their numbers in this assay, from the lowest: compounds 2, 4 and 1 (each within the scatter of the next); then compound 3.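

Moving the nitro group matters in this assay even though the atoms stay the same (a 2.8-fold lower number from compound 3 to compound 4 (0.44 log units; beyond the scatter)), which the earlier compounds could not show. As 3-nitrophenyl, the group leaves the number within the scatter of the plain phenyl (a 1.1-fold lower number from compound 1 to compound 4 (0.06 log units; within the scatter)) and of 4-methoxyphenyl (a 1.0-fold higher number from compound 2 to compound 4 (0.01 log units; within the scatter)), so among these four compounds only compound 3 stands apart.

As far as these compounds go, whether that gap belongs to the nitro group itself, or would also appear with an amine or a chlorine in its place in 2-nitrophenyl, stays open. No evidence here explains the difference between the two positions.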